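A few compounds are considered here, and "the series" means these few. Any claim that something is new, unique, unknown or untested is made for them only; others in the source may bear on it.

Working notes on the series. Among the compounds with values here, compound 2 `Cc1cccc(C(=O)Nc2ccc3c(c2)C[C@@H](NS(C)(=O)=O)C3)c1-c1ccc(C(F)(F)F)cc1` gives 8.8 nM in an assay for inhibition of apolipoprotein B-100 (Homo sapiens), tested at 100 nM; a lower number here means a stronger inhibitor, a higher number a weaker inhibitor; this is the higher of the two numbers measured so far, and the nearest is compound 1 `COC(=O)N[C@H]1Cc2ccc(NC(=O)c3cc(C(F)(F)F)ccc3-c3ccc(C(F)(F)F)cc3)cc2C1`, which in this assay gives 7.5 nM, a gap within the scatter. Compound 3 `Cc1cccc(C(=O)Nc2ccc3c(c2)C[C@H](NS(C)(=O)=O)C3)c1-c1ccc(C(F)(F)F)cc1` is the next compound to be measured in this assay. The change is the two compounds have the same atoms and bonds and differ only in configuration as drawn: 1 of 1 stereo elements differ; a stereocentre at a saturated ring carbon is drawn S in compound 2 and R in compound 3. Within the data shown here, no pair of measured compounds in this assay differs only in configuration at this centre, so the data give no measured step of this kind to lean on. The expectation rests on the general observation that inverting a single stereocentre in an otherwise fixed structure more often loses potency than gains it, so compound 3 is expected to show a weaker number, with a step of a 6.8-fold higher number from compound 2 to compound 3 (0.83 log units; beyond the scatter) that goes beyond the scatter. For compound 3 the estimate in this assay is 60 nM, with a range from 10 nM to 600 nM.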

Compound 3, half-maximal inhibitory concentration: 1.8 nM
For compound 3 the middle estimate is 33-fold (1.52 log units) above the measured one, outside the stated range (below it).
By their numbers in this assay, from the lowest: compound 3; then compounds 1 and 2 (each within the scatter of the next).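

Within the data shown here, compound 2 and compound 3 are the first pair that isolates the stereocentre at the saturated ring carbon, and in this assay they show a 4.9-fold lower number from compound 2 to compound 3 (0.69 log units; beyond the scatter), with the lower number on the form drawn R. The step can be assigned to this centre alone because nothing else changes: the fact that compounds 2 and 3 differ only in the configuration as drawn. Inversion here tunes the number rather than abolishing inhibition, since compound 2, the form drawn S, still gives 8.8 nM.

The compounds shown leave open whether the form drawn R is also favoured with another group on this carbon, such as the methyl carbamate of compound 1, a free amine or a carboxylic acid. From the compounds shown here alone, whether the size of the step holds when the methyl group gives way to trifluoromethyl also stays open.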